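Swapping a Nitro Group for a Methoxy Group

The source may hold more compounds than are shown below. What is called first, only, known or untested is meant among the compounds shown, and "the series" means these compounds.

Measured compounds:
Compound 1 `COc1cc(C2CC(c3ccc([N+](=O)[O-])cc3)=NN2C(C)=O)ccc1OCc1cn(Cc2ccc([N+](=O)[O-])cc2)nn1` gives 7%
Compound 2 `COc1ccc(C2CC(c3ccc(OCc4cn(Cc5ccc([N+](=O)[O-])cc5)nn4)cc3)=NN2C(C)=O)cc1` gives 15%
Compound 3 `CC(=O)N1N=C(c2ccc(OCc3cn(Cc4ccc([N+](=O)[O-])cc4)nn3)cc2)CC1c1ccccc1` gives 0%

In a functional assay on THP-1 cells (Homo sapiens) for inhibition, read by sulforhodamine B assay, tested at 10 uM (a higher number here means more inhibition of growth at the concentration tested, a lower number less inhibition of growth), compound 1 stands second highest of the three numbers, but its gaps to compound 3 and to compound 2 both lie within the scatter, so no real order among the three can be read from them; all three numbers are low. Compound 4 `COc1ccc(C2=NN(C(C)=O)C(c3ccc(OCc4cn(Cc5ccc([N+](=O)[O-])cc5)nn4)c(OC)c3)C2)cc1` differs from compound 1 by methoxy in place of nitro on an aromatic carbon. Going by the values given here, no measured step covers this particular change. Among the compounds with values here, the only measured step, a number 15 percentage points lower from compound 2 to compound 3 (beyond the scatter), concerns a different group at a different place, so it gives only indirect guidance: it shows that a single substituent swap in this set can move the read-out by a modest amount. Compound 2 already carries the 4-methoxyphenyl that enters in compound 4, and compound 2 gives 15%. Within the data shown here, with every measured number low and no direct precedent, the step is expected to stay small, a number 5 percentage points higher from compound 1 to compound 4 (within the scatter), with no clear direction beyond the scatter. Compound 4 is therefore estimated at 12%, expected to fall between 0% and 25%.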

Compound 4, percent growth inhibition at one concentration: 8%
The estimate for compound 4 lay 4 percentage points above the measured number; the range from low to high includes it.
By their numbers in this assay, from the lowest: compounds 3, 1, 4 and 2 (each within the scatter of the next, the first and the last beyond it).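

Going by these compounds alone, the 4-nitrophenyl to 4-methoxyphenyl change gives a number 1 percentage points higher from compound 1 to compound 4 (within the scatter) in this assay and is the first measured step at this position. The two groups, though different in their atoms, cannot be told apart here on an aromatic carbon para to a large group, whereas the change elsewhere in the set gives a number 15 percentage points lower from compound 2 to compound 3 (beyond the scatter) and does exceed the scatter. Nothing available explains why this swap leaves the read-out within the scatter.

From the compounds shown here alone, whether an amine or a carboxylic acid on this same carbon would move the number beyond the scatter remains open. Going by these compounds, it is also open whether the swap from nitro to methoxy would read the same on the core of compound 3, which lacks the methoxy group of compound 1.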